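A few compounds are considered here, and "the series" means these few. Any claim that something is new, unique, unknown or untested is made for them only; others in the source may bear on it.

- compound 1 `COc1cc(/C=C2\CN(C)C/C(=C\c3ccc(F)cc3)C2=O)cc(OC)c1OC`: 7250 nM
- compound 2 `COc1cc(/C=C2\CN(C)C/C(=C\c3ccc(Cl)cc3)C2=O)cc(OC)c1OC`: > 20000 nM (a limit of the assay, not a number)

Both compounds were tested in a functional assay on HeLa cells (Homo sapiens) for cytotoxicity, read by MTT assay, with a stated time of 24 h; on this read-out lower numbers stand for stronger inhibition and higher numbers for weaker inhibition. Compound 2 stands at the limit of > 20000 nM in this assay, at which 1 of the 2 values shown sits, so it has only a limit and no exact place on the scale.

The next compound, compound 3 `COc1cc(/C=C2\CN(C)C/C(=C\c3ccc(Br)cc3)C2=O)cc(OC)c1OC`, differs from compound 2 by one swap, bromo in place of chloro on an aromatic carbon. The group sits para to a large group on a six-membered aromatic ring of carbon only.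

Within the data shown here, only one measured step bears on this change: an at least 2.7-fold higher number from compound 1 to compound 2 (0.44 log units; beyond the scatter). That step also exchanged one halogen for another, and it was beyond the scatter. From the compounds shown here alone, its true size remains open, however, since it ends at a limit. A single step of this kind gives no firm direction for the next swap, so no step beyond the scatter is expected in this assay.

The expected change is a number no higher from compound 2 to compound 3 (the limit leaves the size open). Compound 3 is estimated at 20000 nM, with an expected range from 7000 nM to 50000 nM.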

Compound 3, half-maximal inhibitory concentration: 11900 nM
For compound 3 the middle estimate is 1.7-fold (0.23 log units) above the measured one; measured number inside the range.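

Changing the halogen at this place on the ring need not move the result beyond the usual scatter in this assay: the fluoro and bromo versions show a 1.6-fold higher number from compound 1 to compound 3 (0.22 log units; within the scatter). Exchanging chloro for bromo gives an at least 1.6-fold lower number from compound 2 to compound 3 (0.22 log units; that floor lies within the scatter), so this step has only a floor, and that floor alone does not establish a real difference between the two halogens. Compound 2 has a limit of the assay rather than an exact value, which leaves the true size of this step unknown: the limit of > 20000 nM in this assay, at which 1 of the 3 values shown sits.

The compounds shown leave open where compound 2 would fall on the scale, and therefore whether chloro really stands apart from fluoro and bromo or only appears to because its value is a limit. They also leave open how this cell-killing read-out would respond if a halogen at this place on the ring were replaced by an entirely different group, such as an amine or a carboxylic acid.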